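Sulfonyl benzamide anilides: methyl-to-hydrogen step on the chain

This account rests on a few compounds, and the source may have more. Where it says the series, first, only, none or still open, it means among the compounds named here.

Measured so far in a functional assay for inhibition, read by spectrophotometry, with a stated time of 20 min, tested at 3 mg/mL; on this read-out higher numbers stand for a stronger effect at the one concentration tested and lower numbers for a weaker effect:
compound 1, `CCC(C)C(C(=O)Nc1ccc(C(C)=O)cc1)N(C(=O)c1ccccc1)S(=O)(=O)c1ccc(C)cc1`, gives 33.4%
compound 2, `CC(=O)c1ccc(NC(=O)C(C(C)C)N(C(=O)c2ccccc2)S(=O)(=O)c2ccc(C)cc2)cc1`, gives 29.7%
compound 3, `CCC(C)C(C(=O)Nc1ccc(C(C)=O)cc1)N(C(=O)c1ccccc1)S(=O)(=O)c1ccc([N+](=O)[O-])cc1`, gives 42.1%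

Compound 2 differs from compound 1 by hydrogen in place of methyl on a saturated chain carbon, three bonds along the chain from an amide-type nitrogen and a carbonyl carbon, and this step read a number 3.7 percentage points lower from compound 1 to compound 2 (within the scatter). Compound 3 differs from compound 1 by nitro in place of methyl on an aromatic carbon, with a number 8.7 percentage points higher from compound 1 to compound 3 (within the scatter). Compound 4, `CC(=O)c1ccc(NC(=O)C(C(C)C)N(C(=O)c2ccccc2)S(=O)(=O)c2ccc([N+](=O)[O-])cc2)cc1`, has not yet been measured; it differs from compound 3 by hydrogen in place of methyl on a saturated chain carbon, three bonds along the chain from an amide-type nitrogen and a carbonyl carbon, the same change that separates compound 1 from compound 2, made here on the core of compound 3. Since that earlier step stayed within the scatter, the step from compound 3 to compound 4 is expected to be small as well, about a number 3.6 percentage points lower from compound 3 to compound 4 (within the scatter). Compound 4 is therefore estimated at 38.5%, expected to fall between 27% and 50%.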

Compound 4, a percentage reported as inhibition, at one concentration (the size of the read-out at that concentration, not a potency): 29.8%
Compound 4: middle estimate off by 8.7 percentage points, on the high side, within the range that was stated.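

In this assay, the change from sec-butyl to isopropyl read a number 12.3 percentage points lower from compound 3 to compound 4 (beyond the scatter), yet it cannot be told apart from the same change on the other core: the same change on two cores in this assay, a number 3.7 percentage points lower (within the scatter) from compound 1 to compound 2 and a number 12.3 percentage points lower (beyond the scatter) from compound 3 to compound 4, 8.6 percentage points apart, within the scatter of two such steps
Nitro in place of methyl on the aromatic carbon, made on the isopropyl core, read a number 0.1 percentage points higher from compound 2 to compound 4 (within the scatter), and this step also agrees with its counterpart: the same change on two cores in this assay, a number 8.7 percentage points higher (within the scatter) from compound 1 to compound 3 and a number 0.1 percentage points higher (within the scatter) from compound 2 to compound 4, 8.6 percentage points apart, within the scatter of two such steps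
Within the data shown here, the steps are thus compatible with the change carrying from one core to the other, but two cores do not show that it carries across the series, nor do they show that the core has no influence on the step.

Going by these compounds, it remains open how a longer chain would read in place of the sec-butyl group. The same holds for an amine or a carboxylic acid in place of the nitro group.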